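A heavier halogen on the same aromatic carbon

The compounds below may be only part of what the source reports. "The series", "measured", "known", "first", "only" and "open" are said of these compounds alone.

Compound 1 `CN(C)C(=O)c1cc2cnc(Nc3ccc(NC(=O)C4(C(=O)Nc5cccc(F)c5)CC4)cc3)nc2n1C1CCCC1` stands lowest of the three numbers in a functional assay on T47D cells (Homo sapiens) for inhibition, read by CCK-8 assay, with a stated time of 72 h, tested at 1 uM (a higher number here means more inhibition of growth at the concentration tested, a lower number less inhibition of growth), giving -3.2%. Compound 2 `Cc1ccc(NC(=O)C2(C(=O)Nc3ccc(Nc4ncc5cc(C(=O)N(C)C)n(C6CCCC6)c5n4)cc3)CC2)cc1` gives 47.9% and compound 3 `COc1cccc(NC(=O)C2(C(=O)Nc3ccc(Nc4ncc5cc(C(=O)N(C)C)n(C6CCCC6)c5n4)cc3)CC2)c1` gives 56.3%, and the step of a number 8.4 percentage points higher from compound 2 to compound 3 (within the scatter) lies within the scatter. Compound 4 `CN(C)C(=O)c1cc2cnc(Nc3ccc(NC(=O)C4(C(=O)Nc5cccc(Br)c5)CC4)cc3)nc2n1C1CCCC1` differs from compound 1 by bromo in place of fluoro on an aromatic carbon. Going by the values given here, no measured step is this exact change, but both measured steps start from compound 1 and replace its 3-fluorophenyl with another ring: a number 51.1 percentage points higher from compound 1 to compound 2 (beyond the scatter) and a number 59.5 percentage points higher from compound 1 to compound 3 (beyond the scatter), each large and upward. The step from compound 1 to compound 4 is therefore expected to be upward as well, estimated at a number 33.2 percentage points higher from compound 1 to compound 4 (beyond the scatter). How far a bromo alone carries it is uncertain, so compound 4 is expected to reach 30%, between -5% and 60%.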

Compound 4, percent growth inhibition at one concentration: 29.1%
For compound 4 the middle estimate is 0.9 percentage points above the measured one; measured number inside the range.
By their numbers in this assay, from the lowest: compound 1; then compound 4; then compounds 2 and 3 (each within the scatter of the next).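

In this assay the halogen on this aromatic carbon proves to matter by itself, since bromo alone gives a large rise (a number 32.3 percentage points higher from compound 1 to compound 4 (beyond the scatter)) with no ring added and no hydrogen-bond donor or acceptor involved. That rise still falls short of the other two compounds (a number 27.2 percentage points lower from compound 3 to compound 4 (beyond the scatter); a number 18.8 percentage points lower from compound 2 to compound 4 (beyond the scatter)), so bromo recovers only part of the growth inhibition they show. No evidence here bears on this result. The compounds shown leave open how chloro, a nitrile or a carboxylic acid on the same aromatic carbon would compare.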